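Phenyl for Allyl on a Ring Nitrogen: Expected Edema Inhibition

The source may hold more compounds than are shown below. What is called first, only, known or untested is meant among the compounds shown, and "the series" means these compounds.

Measured in a functional assay on the whole organism (strain albino) for inhibition, with Rattus norvegicus as the target, read by paw edema, with stated times of 30 min and 2 h, at a dose of 0.28 mmol/kg by the oral route; on this read-out lower numbers stand for less inhibition and higher numbers for more inhibition at the one dose given (going by the name of the read-out):
compound 1 `COc1ccc(-c2nnc(SCC(=O)Nc3ccc(/C(C)=N/O)cc3)n2-c2ccccc2)cc1OC` gives 63%
compound 2 `C=CCn1c(SCC(=O)Nc2ccc(/C(C)=N/O)cc2)nnc1-c1ccc(OC)c(OC)c1` gives 56%
compound 3 `C=CCn1c(SCC(=O)Nc2ccc(C(C)=O)cc2)nnc1-c1ccc(OC)cc1` gives 51%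

Compound 1 and compound 2 differ in one place: phenyl in place of allyl on an aromatic nitrogen. This change gave a number 7 percentage points higher from compound 2 to compound 1 (within the scatter). Compound 4 `COc1ccc(-c2nnc(SCC(=O)Nc3ccc(C(C)=O)cc3)n2-c2ccccc2)cc1` is not yet measured; it arises from compound 3 through (phenyl in place of allyl on an aromatic nitrogen). The difference between the cores of compound 3 and compound 2 is not broken down here, and the surroundings of the changed position differ too: the ring atom next to it bears a 3,4-dimethoxyphenyl group in one pair and a 4-methoxyphenyl group in the other, so the two changes are of the same kind rather than the same. Among the measured compounds shown here, only one earlier step exists, and it stayed within the scatter. Compound 4 is therefore expected to show a step of about a number 6 percentage points higher from compound 3 to compound 4 (within the scatter), resting on that earlier step. Compound 4 is estimated at 57%, with a range from 45% to 68%.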

Compound 4, a percentage reported as inhibition, in the whole organism at one dose (the size of the read-out at that dose, not a potency): 42%
Estimate against measurement, compound 4: 15 percentage points above; measured number below the stated range.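

Putting phenyl in place of allyl on the aromatic nitrogen in this assay gave a number 9 percentage points lower from compound 3 to compound 4 (within the scatter), a step that taken alone stays within the usual noise of the measurement. Set beside the earlier step, however, it shows that the change did not carry over from one core to the other as a fixed amount: the same change on two cores in this assay, a number 7 percentage points higher (within the scatter) from compound 2 to compound 1 and a number 9 percentage points lower (within the scatter) from compound 3 to compound 4, 16 percentage points apart, beyond the scatter of two such steps This does not show what sets the two cores apart, as the two pairs differ in more than one feature, including a 3,4-dimethoxyphenyl group in one pair and a 4-methoxyphenyl group in the other, and the data do not separate these features.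

The compounds shown leave open how other groups on that nitrogen, such as a benzyl group or a longer chain like hexyl, would behave on either core.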